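This account rests on a few compounds, and the source may have more. Where it says the series, first, only, none or still open, it means among the compounds named here.

Compound 1 `COc1ccc(NC(=O)CSc2nc3cc(Br)cnc3[nH]2)cc1OC` is measured in an assay on isolated protein for inhibition of Ectonucleotide pyrophosphatase/phosphodiesterase family member 1 (Homo sapiens) (on this read-out higher numbers stand for weaker inhibition and lower numbers for stronger inhibition), where compound 1 gives 192 nM. Compound 2 `COc1ccc(NC(=O)CSc2nc3c(N)nc(SC)nc3[nH]2)cc1OC` sits close to it: in this assay compound 2 gives 152 nM, and the two numbers lie within the usual scatter of each other, so neither stands apart. Compound 3 `COc1ccc(NC(=O)CSc2nc3cc(Cl)cnc3[nH]2)cc1OC` has not yet been measured. It differs from compound 1 by one change, (chloro in place of bromo on an aromatic carbon). Going by the values given here, no measured pair shows this exchange, so the expected step from compound 1 to compound 3 in this assay, a 1.3-fold higher number from compound 1 to compound 3 (0.11 log units; within the scatter), is small, if anything toward weaker inhibition. Compound 3 is therefore estimated at 250 nM, within 120 nM to 550 nM.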

Compound 3, inhibition constant: 137 nM
Beside the measured number, compound 3's estimate is 1.8-fold (0.26 log units) above it; measured number inside the range.
By their numbers in this assay, from the lowest: compounds 3, 2 and 1 (each within the scatter of the next).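

In this assay, the chloro in place of bromo on this aromatic carbon gives a 1.4-fold lower number from compound 1 to compound 3 (0.15 log units; within the scatter) and so leaves the number within the scatter. Going by these compounds alone, this is the first reading of a change made in one place, as compound 1 and compound 2 differ in more than one place. At this position, bromo and chloro cannot be told apart. On these data alone, whether hydrogen, methyl, an amine or a carboxylic acid on this carbon would move the number beyond the scatter remains open. Nothing available bears on why bromo and chloro read alike.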